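Methoxy for chloro: expected tolerance of compound 4

This account rests on a few compounds, and the source may have more. Where it says the series, first, only, none or still open, it means among the compounds named here.

In an ADME assay on Jurkat cells (Homo sapiens) for cytotoxicity, read by WST assay, with a stated time of 48 h (a higher number here means that more compound is tolerated, a lower number that less compound is tolerated), compound 1 `Cc1ccc(Nc2nc(-c3ccccc3)c(C#N)c(N3CCCCC3)n2)cc1` gives > 10000 nM, which is a limit of the assay and not a number. Compound 2 `N#Cc1c(-c2ccc(Cl)cc2)nc(SCc2ccccc2)nc1N1CCC(C(N)=O)CC1` also gives only a limit, > 10000 nM. Compound 3 `N#Cc1c(-c2ccc(Cl)cc2)nc(SCc2ccccc2)nc1N1CCC(C(=O)c2ccccc2)CC1` likewise returns a limit, > 10000 nM. Within the data shown here, the one single-point step recorded so far, a step that the two limits leave unreadable from compound 2 to compound 3, cannot be sized, because the limit of > 10000 nM in this assay, at which 3 of the 3 values shown sit, is where all three values sit. Compound 3 therefore stands at the limit, indistinguishable on these numbers from the other two.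

Compound 4 `COc1ccc(-c2nc(SCc3ccccc3)nc(N3CCC(C(=O)c4ccccc4)CC3)c2C#N)cc1` differs from compound 3 by methoxy in place of chloro on an aromatic carbon. Among the measured compounds shown here, no measured step bears directly on this change, and the only recorded step, a step that the two limits leave unreadable from compound 2 to compound 3, gives no readable size to lean on. For the measured compounds named here, with every value so far at the limit, the expectation for compound 4 in this assay is that it too is tolerated up to the limit, so the step that the limit leaves unreadable from compound 3 to compound 4 is expected to be no change beyond the scatter. The estimate for compound 4 is 15000 nM, within a range of 5000 nM to 50000 nM.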

Compound 4, half-maximal cytotoxic concentration: > 10000 nM
Compound 4: no number, only a limit (the forecaster's own chance of this, stated with the estimate: 85%); the middle value does not contradict the limit.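

No step can be read from compound 3 to compound 4, as both results are limits and not numbers: the limit of > 10000 nM in this assay, at which 4 of the 4 values shown sit.

As far as these compounds go, how far the tolerated concentrations of compound 3 and compound 4 lie past that limit in this assay, and whether methoxy and chloro differ there at all, stays open.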